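A few compounds are considered here, and "the series" means these few. Any claim that something is new, unique, unknown or untested is made for them only; others in the source may bear on it.

Working notes on the series: in a functional assay on cells (Cancer cell lines, Homo sapiens) for inhibition (on this read-out higher numbers stand for weaker inhibition of growth and lower numbers for stronger inhibition of growth), compound 1 (`Cc1cc(-c2nc3sc(C)cn3c2/C=N/NC(=N)N)c(C)s1`) gives 18200 nM and compound 2 (`N=C(N)N/N=C/c1c(-c2cc(Cl)sc2Cl)nc2n1CCS2`) gives 17400 nM. Compound 2 therefore stands within the scatter of compound 1, and the two values cannot be ordered. The next compound to be read is compound 3 (`N=C(N)N/N=C/c1c(-c2cccs2)nc2n1CCS2`), which carries thiophen-2-yl in place of the 2,5-dichlorothiophen-3-yl of compound 2 on an aromatic carbon: thiophen-2-yl in place of 2,5-dichlorothiophen-3-yl on an aromatic carbon. Among the compounds with values here, no measured pair isolates this change, and compound 1 and compound 2 differ in more than one place, so the expectation has little direct support. A small move towards weaker inhibition in this assay is expected, close to the scatter, and the estimated change is a 1.4-fold higher number from compound 2 to compound 3 (0.14 log units; within the scatter). For compound 3 the expected value is 24000 nM, within an estimated range of 11000 nM to 55000 nM.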

Compound 3, concentration for total growth inhibition: 39800 nM
For compound 3 the middle estimate is 1.7-fold (0.22 log units) below the measured one, within the range that was stated.
By their numbers in this assay, from the lowest: compounds 2 and 1 (each within the scatter of the next); then compound 3.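

In this assay, within the data shown here, the aromatic carbon next to the ring nitrogen now gives the first single-place reading: thiophen-2-yl in place of 2,5-dichlorothiophen-3-yl gives a 2.3-fold higher number from compound 2 to compound 3 (0.36 log units; beyond the scatter). The substituent at this position therefore affects the read-out, with a modest step in the direction of weaker inhibition of growth. The change removes both chlorine atoms and also alters the point of attachment on the thiophene, and no measurement on hand bears on why the number rises.

The compounds shown do not separate the chlorine atoms from the point of attachment, a question that unsubstituted thiophen-3-yl would address directly. Also open, from the compounds shown here alone, is how the position responds to a group of another kind, such as phenyl or an amine.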